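From 2-ethoxyethyl to 3-ethoxypropyl in the side chain

The compounds below may be only part of what the source reports. "The series", "measured", "known", "first", "only" and "open" are said of these compounds alone.

In a functional assay on the whole organism for inhibition, with Felis catus as the target, with a stated time of 30 min (on this read-out lower numbers stand for an effect already at smaller amounts and higher numbers for an effect only at larger amounts of compound), compound 3 `CCOCCNCC(O)COc1ccccc1` gives 0.047 mg/kg. Compound 1 `OC(CNCCOc1ccccc1)COc1ccccc1` gives 0.054 mg/kg, which places it level with compound 3, with a 1.1-fold lower number from compound 1 to compound 3 (0.06 log units; within the scatter). Compound 2 `COCCNCC(O)COc1ccccc1` gives 0.13 mg/kg, with a 2.4-fold higher number from compound 1 to compound 2 (0.38 log units; beyond the scatter).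

The next structure is compound 4 `CCOCCCNCC(O)COc1ccccc1`, which differs by ethoxymethyl in place of ethoxy on a saturated chain carbon, two bonds along the chain from an amine nitrogen. Cut one bond further out, the same difference reads 2-ethoxyethyl to 3-ethoxypropyl.

Among the measured compounds shown here, no measured step makes exactly this change. The closest is the methyl-for-hydrogen change, with a 2.8-fold lower number from compound 2 to compound 3 (0.44 log units; beyond the scatter), which is modest. The exchange of phenyl for ethyl stayed within the scatter, so the side chain has so far moved the numbers only modestly. A step within the scatter is therefore expected, with no firm direction. The expected step is a 1.3-fold higher number from compound 3 to compound 4 (0.11 log units; within the scatter). For compound 4 the estimated value is 0.06 mg/kg, with an expected range of 0.02 mg/kg to 0.18 mg/kg.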

Compound 4, dose for half-maximal effect: 0.066 mg/kg
Estimate against measurement, compound 4: 1.1-fold (0.04 log units) below, and the stated range covers the measured number.
By their numbers in this assay, from the lowest: compounds 3, 1, 4 and 2 (each within the scatter of the next, the first and the last beyond it).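

In this assay this position accepts 2-ethoxyethyl going to 3-ethoxypropyl without a step beyond the scatter (a 1.4-fold higher number from compound 3 to compound 4 (0.15 log units; within the scatter)), and ethoxymethyl in place of phenoxy at the same place also stays within it (a 1.2-fold higher number from compound 1 to compound 4 (0.09 log units; within the scatter)). Ethoxymethyl in place of methoxy likewise stays within the scatter (a 2.0-fold lower number from compound 2 to compound 4 (0.29 log units; within the scatter)), whereas the step to the ethoxyethyl chain lies beyond it (a 2.8-fold lower number from compound 2 to compound 3 (0.44 log units; beyond the scatter)), so only that step separates compound 2 from the others. No measurement at hand explains these steps.

As far as these compounds go, whether a longer chain such as 4-ethoxybutyl still stands level with compound 1, compound 3 and compound 4 stays open. So does the outcome with an amine or a carboxylic acid at the end of this side chain.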